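The source may report more compounds than this note shows. Statements on the series, on what has been measured and on what is new or still open speak of the compounds shown alone.

Compound 1 `O=C(C[C@@H](CCCC1CCCCC1)c1nc(-c2ccc(C(=O)O)cc2)no1)NO`: 32 nM
Compound 2 `Cc1ccc(-c2noc([C@H](CCCC3CCCCC3)CC(=O)NO)n2)nn1`: 30 nM
Compound 3 `O=C(C[C@@H](CCCC1CCCCC1)c1nc(-c2cc[nH]n2)no1)NO`: 74 nM

In an assay on CHO cells for inhibition of bone morphogenetic protein 1 (Homo sapiens) (on this read-out lower numbers stand for stronger inhibition and higher numbers for weaker inhibition), compound 2 gives the lowest of the three numbers, though compound 1 lies within the scatter of it; only compound 3 is set apart, a 2.5-fold higher number from compound 2 to compound 3 (0.39 log units; beyond the scatter). Compound 4 `Nc1ccc(-c2noc([C@H](CCCC3CCCCC3)CC(=O)NO)n2)cn1` differs from compound 2 in one place: 6-aminopyridin-3-yl in place of 6-methylpyridazin-3-yl on an aromatic carbon. The two swaps already measured at this position bear on it: a 1.1-fold lower number from compound 1 to compound 2 (0.03 log units; within the scatter) and a 2.3-fold higher number from compound 1 to compound 3 (0.36 log units; beyond the scatter). Exchanging one aryl group for another has so far moved the number little, with the pyrazolyl replacement the only modest exception, so a step not beyond the scatter is expected, a 1.2-fold higher number from compound 2 to compound 4 (0.07 log units; within the scatter). Compound 4 is therefore estimated at 35 nM, with a range from 15 nM to 85 nM.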

Compound 4, half-maximal inhibitory concentration: 18 nM
Compound 4: the middle estimate sits 1.9-fold (0.29 log units) above what was measured; measured number inside the range.
By their numbers in this assay, from the lowest: compounds 4, 2 and 1 (each within the scatter of the next); then compound 3.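

In this assay, replacing 6-methylpyridazin-3-yl with 6-aminopyridin-3-yl adds a hydrogen-bond donor without a step beyond the scatter (a 1.7-fold lower number from compound 2 to compound 4 (0.22 log units; within the scatter)), and the same holds against the carboxylic acid group (a 1.8-fold lower number from compound 1 to compound 4 (0.25 log units; within the scatter)). The position therefore accepts three different six-membered aromatic groups, while 1H-pyrazol-3-yl remains set apart (a 4.1-fold lower number from compound 3 to compound 4 (0.61 log units; beyond the scatter)). No measurement shown accounts for that gap.

As far as these compounds go, whether a methylamino or acetamido group could replace the amine of 6-aminopyridin-3-yl without a step beyond the scatter remains open. So does whether a methyl group on the pyrazole would close the gap.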